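The source may report more compounds than this note shows. Statements on the series, on what has been measured and on what is new or still open speak of the compounds shown alone.

Compounds measured in a functional assay on NALM-6 cells (Homo sapiens) for cytotoxicity, with a stated time of 72 h (a higher number here means that more compound is needed for the effect, a lower number that less compound is needed), where each value is a limit of the assay and not a number:

Compound 1 `C=C[C@@](C)(/C=C/c1ccc(O)c(/C=C(\C)C(=O)OCC)c1)CCC=C(C)C`: > 7500 nM
Compound 2 `COc1ccc(/C=C/[C@@](C)(/C=C/c2ccc(O)c(C=O)c2)CCC=C(C)C)cc1`: > 43400 nM
Compound 3 `CCOC(=O)/C=C/c1cc(/C=C/[C@](C)(/C=C/c2ccc(OC)cc2)CCC=C(C)C)ccc1O`: > 43400 nM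

Compound 3 has no numerical reading, only the limit > 43400 nM. This places it at the limit of > 43400 nM in this assay, at which 2 of the 3 values shown sit, a position it shares with compound 2. The remaining value, for compound 1, stands at the limit of > 7500 nM in this assay, at which 1 of the 3 values shown sits.

Compound 4 `CCOC(=O)/C(C)=C/c1cc(/C=C/[C@](C)(/C=C/c2ccc(OC)cc2)CCC=C(C)C)ccc1O` departs from compound 3 in one place: 2-(ethoxycarbonyl)prop-1-en-1-yl in place of 2-(ethoxycarbonyl)ethenyl on an aromatic carbon. Thus 2-(ethoxycarbonyl)prop-1-en-1-yl replaces 2-(ethoxycarbonyl)ethenyl on an aromatic carbon, ortho to a hydroxy group.

Within the data shown here, the only measured step at this place is a step that the two limits leave unreadable from compound 2 to compound 3, so it offers no size to carry over. Compound 1 carries the same 2-(ethoxycarbonyl)prop-1-en-1-yl group, but the rest of its structure differs, and it too gives only a limit. Nothing measured therefore points to a step beyond the scatter, or to a direction. The expected result is a number no higher from compound 3 to compound 4 (the limit leaves the size open), an estimate resting on limits alone. Compound 4 is estimated at 43400 nM, with an expected range of 15000 nM to 90000 nM. The most likely outcome in this assay is that it again yields only a limit.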

Compound 4, half-maximal effective concentration: > 43400 nM
Compound 4 ended at the assay's limit; the forecaster's own chance of this, stated with the estimate: 80%; the middle value lies on the limit itself.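

In this assay compound 4 gives > 43400 nM, which is a limit of the assay and not a number. Among these compounds, compound 1, compound 2 and compound 3 also give only limits, so no step to compound 4 can be read. The compounds shown leave open whether 2-(ethoxycarbonyl)prop-1-en-1-yl in place of 2-(ethoxycarbonyl)ethenyl changes the concentration needed at all.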